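Methyl in place of 3-methylphenyl on the sulfonyl sulfur

The source may hold more compounds than are shown below. What is called first, only, known or untested is meant among the compounds shown, and "the series" means these compounds.

Three measured compounds share one core and differ only in the group carried by the sulfonyl sulfur. In an assay on cells for inhibition of HSP60/HSP10 (Homo sapiens), with a stated time of 60 min (on this read-out lower numbers stand for stronger inhibition and higher numbers for weaker inhibition), compound 1 `O=S(=O)(Nc1ccc2oc(-c3ccccc3)nc2c1)c1cccc(F)c1` reports only a limit of the assay, > 100000 nM. Compound 2 `O=S(=O)(Nc1ccc2oc(-c3ccccc3)nc2c1)c1ccccc1O` gives 85000 nM in this assay. Compound 3 `Cc1cccc(S(=O)(=O)Nc2ccc3oc(-c4ccccc4)nc3c2)c1` again reports only a limit, > 100000 nM. Compound 3 thus stands at the edge of what this assay can read, a position it shares with one other value (the limit of > 100000 nM in this assay, at which 2 of the 3 values shown sit). The steps among the three are small or unreadable: an at least 1.1-fold lower number from compound 1 to compound 2 (0.07 log units; that floor lies within the scatter), an at least 1.1-fold higher number from compound 2 to compound 3 (0.07 log units; that floor lies within the scatter), and a step that the two limits leave unreadable from compound 1 to compound 3. Compound 4 `CS(=O)(=O)Nc1ccc2oc(-c3ccccc3)nc2c1` carries the change (methyl in place of 3-methylphenyl on a sulfonyl sulfur); the sulfonyl sulfur now bears a group with no ring. The two readable steps, both exchanges of the group on that sulfur, stayed within the scatter, so no step beyond the scatter is expected in this assay: a number no higher from compound 3 to compound 4 (the limit leaves the size open). Compound 4 is therefore estimated at 100000 nM, with a range from 40000 nM to 300000 nM. Most likely that reading would again be only a limit.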

Compound 4, half-maximal inhibitory concentration: > 100000 nM
Compound 4 ended at the assay's limit (the forecaster's own chance of this, stated with the estimate: 75%); the middle value sits exactly at the limit.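

Even with the ring gone, methyl in place of 3-methylphenyl on the sulfonyl sulfur, compound 4 gives only a limit in this assay, so a group with no ring there brings no readable gain. For the compounds shown here, the steps from compound 1 and from compound 3 to compound 4 cannot be read, as both ends of each are limits, and the one readable step is an at least 1.1-fold higher number from compound 2 to compound 4 (0.07 log units; that floor lies within the scatter). This position has now carried ringed groups and a ringless one, and the read-out stays at or close to the ceiling: the limit of > 100000 nM in this assay, at which 3 of the 4 values shown sit.

Going by these compounds, whether any group on this sulfur can give a reading far from that limit stays open. A longer chain in place of methyl, or an amine or a carboxylic acid on the group carried by the sulfur, could answer that.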